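From a Fluorinated Aryl Ring to a Cycloheptyl Ring

A few compounds are considered here, and "the series" means these few. Any claim that something is new, unique, unknown or untested is made for them only; others in the source may bear on it.

Compound 3 `Nc1scc(CN2CCN(c3cccc(C(F)(F)F)c3)CC2)c1C(=O)c1ccc(Cl)cc1` carries a 3-(trifluoromethyl)phenyl group on an amine nitrogen in a ring. In a functional assay on CHO cells with adenosine receptor A1 (Homo sapiens) as the target, read by cAMP accumulation and immunoassay, with a stated time of 6 min, tested at 10 uM (a higher number here means a weaker effect of the compound at the concentration tested, a lower number a stronger effect), compound 3 gives -80%, the lowest of the three numbers measured. Compound 1 `Nc1scc(CN2CCN(c3ccc(F)cc3Cl)CC2)c1C(=O)c1ccc(Cl)cc1` gives -70% in this assay, and compound 2 `COc1ccc(N2CCN(Cc3csc(N)c3C(=O)c3ccc(Cl)cc3)CC2)cc1` gives -52%. The step of a number 10 percentage points lower from compound 1 to compound 3 (within the scatter) lies within the scatter, whereas a number 18 percentage points higher from compound 1 to compound 2 (beyond the scatter) and a number 28 percentage points lower from compound 2 to compound 3 (beyond the scatter) lie beyond it.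

Compound 4 `Nc1scc(CN2CCN(C3CCCCCC3)CC2)c1C(=O)c1ccc(Cl)cc1` differs from compound 3 in one place: cycloheptyl in place of 3-(trifluoromethyl)phenyl on an amine nitrogen in a ring. The measured steps all exchange one aromatic group for another, so none of them covers a seven-membered non-aromatic ring at this position; they do show that such exchanges move the read-out only modestly, as in a number 28 percentage points lower from compound 2 to compound 3 (beyond the scatter). A modest step toward a weaker effect is therefore expected, a number 25 percentage points higher from compound 3 to compound 4 (beyond the scatter). The estimate for compound 4 in this assay is -55%. Given the lack of a direct precedent, the expected range for compound 4 is wide, from -85% to -20%.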

Compound 4, a percentage reported as activity, at one concentration (the size of the read-out at that concentration, not a potency): -25%
Compound 4: the middle estimate sits 30 percentage points below what was measured; low and high end bracket the measured number.
By their numbers in this assay, from the lowest: compounds 3 and 1 (each within the scatter of the next); then compound 2; then compound 4.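

Putting cycloheptyl on the amine nitrogen in a ring gives two large steps in this assay, a number 55 percentage points higher from compound 3 to compound 4 (beyond the scatter) and a number 45 percentage points higher from compound 1 to compound 4 (beyond the scatter), and a modest one, a number 27 percentage points higher from compound 2 to compound 4 (beyond the scatter). For the compounds shown here, all three point the same way, so compound 4, the only one of the four compounds with a non-aromatic ring at this position, shows the weakest effect, and all three compounds with an aromatic ring here, whichever groups that ring carries, show a stronger one. No measurement shown here accounts for this difference.

Still open, going by these compounds, is how a smaller non-aromatic ring such as cyclohexyl, or an open chain such as hexyl, would read at this position. A plain phenyl ring or a pyridine ring on the same nitrogen would also help show how far the aromatic ring itself matters.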